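Ethyl on the Ring Amide Nitrogen: What to Expect

A few compounds are considered here, and "the series" means these few. Any claim that something is new, unique, unknown or untested is made for them only; others in the source may bear on it.

Compound 2 `CC1CCN(c2ccc(Nc3ncc4c(n3)N(C3CCCC3)CC(=O)N4)nc2)CC1` belongs to a small set of three measured compounds sharing one core, all tested in a functional assay on HT-29 cells (Homo sapiens) for inhibition, read by MTT assay, with a stated time of 48 h; a lower number here means a stronger inhibitor, a higher number a weaker inhibitor. In this assay compound 2 reaches only the limit of the assay, > 30000 nM, so no number is known for it. Compound 1 `CN1CCN(c2ccc(Nc3ncc4c(n3)N(C3CCCC3)CC(=O)N4)nc2)CC1` gives 26500 nM in this assay, and the step of an at least 1.1-fold higher number from compound 1 to compound 2 (0.05 log units; that floor lies within the scatter) is therefore a floor rather than a size. Compound 3 `O=C1CN(C2CCCC2)c2nc(Nc3ccc(N4CCNCC4)cn3)ncc2N1` also sits at the limit, > 30000 nM, in this assay. The steps of an at least 1.1-fold higher number from compound 1 to compound 3 (0.05 log units; that floor lies within the scatter) and a step that the two limits leave unreadable from compound 2 to compound 3 rest on the same boundary (the limit of > 30000 nM in this assay, at which 2 of the 3 values shown sit), which leaves their sizes unreadable.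

Compound 4 `CCN1C(=O)CN(C2CCCC2)c2nc(Nc3ccc(N4CCC(C)CC4)cn3)ncc21` differs from compound 2 in one place: ethyl in place of hydrogen on an amide-type nitrogen in a ring. Among the measured compounds shown here, none of the measured steps touches this amide-type nitrogen; all three exchange the saturated ring on an aromatic carbon. For the measured compounds named here, no measured step therefore reads on this change, and with compound 2 itself at the limit, no shift beyond the scatter can be expected. Compound 4 is estimated at 35000 nM, within 12000 nM to 100000 nM. The expected step is a step that the limit leaves unreadable from compound 2 to compound 4, most likely again only a limit.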

Compound 4, half-maximal inhibitory concentration: > 30000 nM
Compound 4: only a limit was reported; the forecaster's own chance of this, stated with the estimate: 75%; the middle value does not contradict the limit.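

No size can be read for the step from compound 2 to compound 4, because both compounds rest on the same boundary: the limit of > 30000 nM in this assay, at which 3 of the 4 values shown sit.

The compounds shown leave open whether ethyl in place of hydrogen on the amide-type nitrogen changes inhibition at all.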